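The source may hold more compounds than are shown below. What is called first, only, known or untested is meant among the compounds shown, and "the series" means these compounds.

Compound 1, with the structure `COc1ccc(C(=O)c2ccc(OC)c3c2OC(C)(C)C=C3)c(NC(=O)CO)c1`, was tested in a functional assay on MCF7 cells (Homo sapiens) for antiproliferative activity, read by MTT assay, with a stated time of 48 h (a higher number here means a weaker inhibitor, a lower number a stronger inhibitor), where compound 1 gives 320 nM. Compound 2, with the structure `COc1ccc(C(=O)c2ccc(OC)c3c2OC(C)(C)C=C3)c(NC(=O)CN)c1`, differs from compound 1 in one place only: amino in place of hydroxy on a saturated chain carbon bound to a carbonyl carbon. In this assay compound 2 gives 410 nM, so the change made a step of a 1.3-fold higher number from compound 1 to compound 2 (0.11 log units; within the scatter). Compound 3, with the structure `C=C(c1ccc(OC)cc1NC(=O)CO)c1ccc(OC)c2c1C=CC(C)(C)O2`, has a different core; the difference between the two cores is not broken down here. In this assay compound 3 gives 590 nM, which sits close to the numbers of compound 1 and compound 2.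

Compound 4, with the structure `C=C(c1ccc(OC)cc1NC(=O)CN)c1ccc(OC)c2c1C=CC(C)(C)O2`, has not yet been measured. It differs from compound 3 in the same way that compound 2 differs from compound 1: amino in place of hydroxy on a saturated chain carbon bound to a carbonyl carbon. Among the measured compounds shown here, since the only measured example of this change, from compound 1 to compound 2, gave a 1.3-fold higher number from compound 1 to compound 2 (0.11 log units; within the scatter), the step from compound 3 to compound 4 is expected to be of about the same small size, a 1.3-fold higher number from compound 3 to compound 4 (0.12 log units; within the scatter). On that basis compound 4 is estimated to give 770 nM in this assay, most likely somewhere between 350 nM and 1700 nM.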

Compound 4, half-maximal inhibitory concentration: 780 nM
Estimate against measurement, compound 4: 1.0-fold (0.01 log units) below; the range from low to high includes it.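

In this assay, putting amino in place of hydroxy on the saturated chain carbon bound to a carbonyl carbon gives a 1.3-fold higher number from compound 3 to compound 4 (0.12 log units; within the scatter), so on the second core, as on the first, the swap leaves the two compounds indistinguishable. The two steps agree: the same change on two cores in this assay, a 1.3-fold higher number (0.11 log units; within the scatter) from compound 1 to compound 2 and a 1.3-fold higher number (0.12 log units; within the scatter) from compound 3 to compound 4, 1.0-fold (0.01 log units) apart, within the scatter of two such steps. This shows that, in this pair of cores, amino and hydroxy can stand in for each other at this place without a measurable difference, but since neither step rises above the scatter, it does not show a real effect of the change that carries over, and it says nothing about any third core.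

The compounds shown leave open what other groups at this place would do, such as a dimethylamino group, a carboxylic acid or a longer chain like aminoethyl. They also leave open whether a change with a step beyond the scatter would carry from one of these cores to the other equally well.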